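Swapping ethoxy for dimethylamino, starting from a limit

The source may report more compounds than this note shows. Statements on the series, on what has been measured and on what is new or still open speak of the compounds shown alone.

Measured in a functional assay on KB cells (Homo sapiens) for inhibition, read by sulforhodamine B assay, with a stated time of 72 h; on this read-out higher numbers stand for weaker inhibition of growth and lower numbers for stronger inhibition of growth:
- compound 1 `CCOC(=O)/C=C/c1ccncc1-c1ccc2[nH]ccc2c1`: > 10000 nM (a limit)
- compound 2 `CCOC(=O)/C=C/c1ccncc1-c1ccc2ccccc2c1`: > 10000 nM (a limit)
- compound 3 `CCOC(=O)/C=C/c1ccncc1-c1ccc2c(ccn2C)c1`: 6250 nM

Compound 2 gives > 10000 nM, and this is a limit, not a number. It therefore marks no exact starting point on the scale, and it sits at the limit of > 10000 nM in this assay, at which 2 of the 3 values shown sit.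

The next compound is compound 4 `CN(C)C(=O)/C=C/c1ccncc1-c1ccc2ccccc2c1`, which has not yet been measured. The change from compound 2 is dimethylamino in place of ethoxy on a carbonyl carbon, or ethoxycarbonyl to dimethylcarbamoyl.

Among the compounds with values here, only one step has been measured: an at least 1.6-fold lower number from compound 1 to compound 3 (0.20 log units; that floor lies within the scatter). That step is methyl in place of hydrogen on an aromatic nitrogen, a different change, so it offers no size to carry over. Within the data shown here, no measured step tests the swap at the carbonyl carbon.

The expected step in this assay is a number no higher from compound 2 to compound 4 (the limit leaves the size open), with no shift beyond the scatter expected in either direction. A further limit is a likely result. For compound 4 the estimated value is 10000 nM, with an expected range of 4000 nM to 25000 nM.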

Compound 4, concentration for 50% growth inhibition: 7760 nM
Compound 4: the middle estimate sits 1.3-fold (0.11 log units) above what was measured; the measured number falls inside the stated range.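

In this assay, within the data shown here, replacing ethoxy with dimethylamino on the carbonyl carbon gives the first reading of this change, and it amounts to an at least 1.2-fold lower number from compound 2 to compound 4 (0.11 log units; that floor lies within the scatter). Compound 4 gives 7760 nM, an actual number on the scale for this core, though the step as printed does not establish a real gain in growth inhibition. Compound 2 gives > 10000 nM, which is a limit and not a number, and it shares this position with one other compound: the limit of > 10000 nM in this assay, at which 2 of the 4 values shown sit.

Still open, on these data alone, is whether another group on the carbonyl carbon, such as a free carboxylic acid, a methylamino group or a longer chain on the amide nitrogen, would move the number beyond the scatter. The swap is also shown on this one pair only, so whether it behaves the same way on the core of compound 3 remains unknown.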